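The source may report more compounds than this note shows. Statements on the series, on what has been measured and on what is new or still open speak of the compounds shown alone.

In a functional assay on SN12C cells (Homo sapiens) for inhibition, read by sulforhodamine B assay, with a stated time of 48 h, tested at 10 uM (on this read-out lower numbers stand for less inhibition and higher numbers for more inhibition at the one concentration tested (going by the name of the read-out)), compound 1, `COc1ccc(-c2cn3ccnc3c(-c3ccc4ncn(C5CCCCC5)c4c3)n2)cc1`, gives 63.6%. Compound 2, `Fc1ccc(-c2cn3ccnc3c(-c3ccc4ncn(C5CCCCC5)c4c3)n2)cc1`, differs from it by fluoro in place of methoxy on an aromatic carbon and gives 3.97% in this assay, so that a number 59.6 percentage points lower from compound 1 to compound 2 (beyond the scatter). Compound 3, `COc1ccccc1-c1cn2ccnc2c(-c2ccc3ncn(C4CCCCC4)c3c2)n1`, shares the same atoms as compound 1 joined differently, the difference being (2-methoxyphenyl in place of 4-methoxyphenyl on an aromatic carbon); in this assay compound 3 gives 7.73%, and a number 55.9 percentage points lower from compound 1 to compound 3 (beyond the scatter). Between the two low members the picture is flat: a number 3.8 percentage points higher from compound 2 to compound 3 (within the scatter).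

Compound 4, `Fc1ccccc1-c1cn2ccnc2c(-c2ccc3ncn(C4CCCCC4)c3c2)n1`, is not yet measured. It differs from compound 3 by fluoro in place of methoxy on an aromatic carbon. This is the same kind of change that leads from compound 1 to compound 2, but not the same: there the fluoro enters para to a large group, here it enters ortho to a large group. The earlier step was large, yet it started from the high value of compound 1. Compound 3 already stands near the bottom of the three numbers, close to compound 2, so the same kind of change is expected to move it only a little this time, and the step of a number 2.7 percentage points lower from compound 3 to compound 4 (within the scatter) is estimated to stay within the scatter. On this basis compound 4 is expected to give about 5% in this assay, most plausibly between -5% and 20%.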

Compound 4, a percentage reported as inhibition, at one concentration (the size of the read-out at that concentration, not a potency): 10.1%
The estimate for compound 4 lay 5.1 percentage points below the measured number; the range from low to high includes it.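

In this assay the exchange of methoxy for fluoro gives a number 2.4 percentage points higher from compound 3 to compound 4 (within the scatter), so it does not carry over from one core to the other, and the step measured on the core of compound 1 cannot be used to predict the step on the core of compound 3: the same change on two cores in this assay, a number 59.6 percentage points lower (beyond the scatter) from compound 1 to compound 2 and a number 2.4 percentage points higher (within the scatter) from compound 3 to compound 4, 62 percentage points apart, beyond the scatter of two such steps. With a number 6.1 percentage points higher from compound 2 to compound 4 (within the scatter) and a number 53.5 percentage points lower from compound 1 to compound 4 (beyond the scatter) as the remaining readings, compound 4 stays with compound 2 and compound 3 in the low group, and of these four compounds only compound 1, which carries 4-methoxyphenyl, stands apart. Among these compounds, this shows that the large loss seen for the fluoro exchange is tied to the one pair that starts from a high value, but it does not show why, and with one pair per core and a single concentration it gives no general rule for other cores or any measure of potency.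

The compounds shown leave open whether the high value of compound 1 depends on the methoxy itself, which could be tested by placing ethoxy, hydroxy, chloro or dimethylamino on the same aromatic carbon. They also leave open whether that value survives when the cyclohexyl ring is exchanged for a smaller group such as cyclopentyl or a longer alkyl chain.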